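Swapping a nitrile for trifluoromethoxy on the amide ring

The compounds below may be only part of what the source reports. "The series", "measured", "known", "first", "only" and "open" are said of these compounds alone.

Measured so far in a functional assay on IMR-32 cells with melanin-concentrating hormone receptor 1 (Homo sapiens) as the target, read by fluorescence; a lower number here means a stronger inhibitor, a higher number a weaker inhibitor:
compound 1 `Nc1ccc2cccc(OCCCNCc3ccc(Cl)c(C(F)(F)F)c3)c2n1` gives 220 nM
compound 2 `CC(C)c1ccc(C(=O)NCCCOc2cccc3ccc(N)nc23)cc1` gives 140 nM
compound 3 `N#Cc1cccc(C(=O)NCCCOc2cccc3ccc(N)nc23)c1` gives 7 nM

Compound 3 has the lowest number of the three, with compound 2 the nearest to it and compound 1 the furthest away. Compound 4 `Nc1ccc2cccc(OCCCNC(=O)c3cccc(OC(F)(F)F)c3)c2n1` keeps the shared core and the amide, but carries trifluoromethoxy in place of cyano on an aromatic carbon. Within the data shown here, the only measured step that bears on this is a 20-fold lower number from compound 2 to compound 3 (1.30 log units; beyond the scatter), which shows that the group on that ring can shift the number a great deal. Compound 1, with its own substituted ring and no amide, stands well above compound 3. Since nothing measured holds a trifluoromethoxy group, compound 4 is expected to lose part of that gain, a step of a 5.7-fold higher number from compound 3 to compound 4 (0.76 log units; beyond the scatter), giving an estimated 40 nM with a range from 10 nM to 160 nM.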

Compound 4, half-maximal inhibitory concentration: 20 nM
Compound 4: middle estimate off by 2.0-fold (0.30 log units), on the high side, within the range that was stated.
By their numbers in this assay, from the lowest: compound 3; then compound 4; then compounds 2 and 1 (each within the scatter of the next).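

In this assay, trifluoromethoxy in place of cyano on this aromatic carbon gives a 2.9-fold higher number from compound 3 to compound 4 (0.46 log units; beyond the scatter) and so costs only a modest amount of strength. Among these compounds, the nitrile is therefore not the only group here that goes with a strong inhibitor, since a larger group containing fluorine also does. Nothing available explains why the nitrile gives the lower number. Still open, from the compounds shown here alone, is how an amine, a carboxylic acid or a methoxy group on this same carbon would compare with these two groups.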